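Lengthening the chain on the amine-bearing carbon of compound 1

The compounds below may be only part of what the source reports. "The series", "measured", "known", "first", "only" and "open" are said of these compounds alone.

Measured so far:
- compound 1, `CCCCCCCCc1ccc(CCC(N)CO)cc1`: > 10 mg/kg
- compound 2, `CCCCCCCOc1ccc(CCC(N)(CC)CO)cc1`: 0.059 mg/kg
- compound 3, `CCCCCCCOc1ccc(CC[C@@](N)(CO)CCO)cc1`: 0.017 mg/kg

Of the compounds shown here, three sharing one core have been tested in a functional assay on the whole organism (spleen, spleen) with Rattus norvegicus as the target; on this read-out lower numbers stand for an effect already at smaller amounts and higher numbers for an effect only at larger amounts of compound. Compound 1 gave no number; its entry is only the limit of the assay, (the limit of > 10 mg/kg in this assay, at which 1 of the 3 values shown sits). Going by the values given here, compound 2 and compound 3, which both carry a fourth substituent on the amine-bearing carbon, are active at small doses, and the single step measured, a 3.5-fold lower number from compound 2 to compound 3 (0.54 log units; beyond the scatter), shows that adding a further hydroxyl-bearing carbon to that group helps modestly.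

Compound 4, `CCCCCCCCc1ccc(CCC(C)(N)CCO)cc1`, is not yet measured. It differs from compound 1 by a group of 6 heavy atoms (4 carbon, 1 nitrogen, 1 oxygen; no ring) in place of a group of 4 heavy atoms (2 carbon, 1 nitrogen, 1 oxygen; no ring), on a saturated chain carbon, two bonds along the chain from an aromatic carbon, so it also gains a fourth substituent on the amine-bearing carbon and a longer hydroxyl-bearing arm, as compound 2 and compound 3 have. Among the compounds with values here, no measured step covers exactly this change, and compound 1 offers only a limit, so the expectation rests on compound 2 and compound 3 being far more potent than compound 1. Compound 4 is therefore expected to move well below the limit, an at least 33-fold lower number from compound 1 to compound 4 (1.52 log units; beyond the scatter), though with wide uncertainty. Compound 4 is estimated at 0.3 mg/kg, within 0.05 mg/kg to 3 mg/kg.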

Compound 4, dose for 50% inhibition: > 10 mg/kg
Compound 4 gave a limit, no number; the forecaster's own chance of this, stated with the estimate: 20%; at least 33-fold (1.52 log units) between middle value and limit.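

Compound 1 and compound 4 both sit at the limit of this assay and neither gives a number, so no step between them can be read: the limit of > 10 mg/kg in this assay, at which 2 of the 4 values shown sit.

The compounds shown leave open how far beyond that limit each one lies, and so whether replacing the 1-amino-2-hydroxyethyl group with the larger group changes the dose needed at all.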